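Reverse of the fluoro step on the phenoxy ring

A few compounds are considered here, and "the series" means these few. Any claim that something is new, unique, unknown or untested is made for them only; others in the source may bear on it.

Measured compounds:
- compound 1 `CN(Cc1ccc(OCCCN)cc1)c1nc2ccc(Oc3ccccc3)cc2s1`: 95000 nM
- compound 2 `CN(Cc1ccc(OCCCNC(=N)N)cc1)c1nc2ccc(Oc3ccc(F)cc3)cc2s1`: 521000 nM
- compound 3 `CN(Cc1ccc(OCCCN)cc1)c1nc2ccc(Oc3ccc(F)cc3)cc2s1`: 492000 nM

In an assay on cells for inhibition of Voltage-dependent T-type calcium channel subunit alpha-1H (Homo sapiens), read by FLIPR and calcium flux, with stated times of 600 s and 300 s (on this read-out lower numbers stand for stronger inhibition and higher numbers for weaker inhibition), compound 2 gives the highest number of the three. Its nearest neighbour is compound 3, which differs only by a hydrogen atom in place of the guanidine-like group on the amine nitrogen, and that step, a 1.1-fold lower number from compound 2 to compound 3 (0.02 log units; within the scatter), is within the scatter. The furthest is compound 1, and the gap to it is beyond the scatter.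

Compound 4 `CN(Cc1ccc(OCCCNC(=N)N)cc1)c1nc2ccc(Oc3ccccc3)cc2s1` is not yet measured. It differs from compound 2 by hydrogen in place of fluoro on an aromatic carbon. Among the compounds with values here, the one measured step that bears on this is a 5.2-fold higher number from compound 1 to compound 3 (0.71 log units; beyond the scatter), the same change run the other way, which was modest but beyond the scatter. The other step, a 1.1-fold lower number from compound 2 to compound 3 (0.02 log units; within the scatter), shows that the amine and its larger substituent do not separate compounds 2 and 3 in this assay, so the fluoro step seen between compounds 1 and 3 is taken as the guide.

Compound 4 is therefore expected to give a lower number than compound 2, a step of about a 5.2-fold lower number from compound 2 to compound 4 (0.72 log units; beyond the scatter). The estimate for compound 4 is 100000 nM, with a range from 40000 nM to 260000 nM.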

Compound 4, half-maximal inhibitory concentration: 498000 nM
Compound 4: the middle estimate sits 5.0-fold (0.70 log units) below what was measured, and the stated range ends below it.
By their numbers in this assay, from the lowest: compound 1; then compounds 3, 4 and 2 (each within the scatter of the next).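

With the guanidine-like group on the amine nitrogen, the change from 4-fluorophenoxy to phenoxy gives a 1.0-fold lower number from compound 2 to compound 4 (0.02 log units; within the scatter) in this assay, so the fluoro step seen with the free amine does not carry over: the same change on two cores in this assay, a 5.2-fold higher number (0.71 log units; beyond the scatter) from compound 1 to compound 3 and a 1.0-fold higher number (0.02 log units; within the scatter) from compound 4 to compound 2, 5.0-fold (0.69 log units) apart, beyond the scatter of two such steps.
The guanidine-like group likewise matters only on the phenoxy side, where it gives a 5.2-fold higher number from compound 1 to compound 4 (0.72 log units; beyond the scatter), and not on the 4-fluorophenoxy side: the same change on two cores in this assay, a 1.1-fold lower number (0.02 log units; within the scatter) from compound 2 to compound 3 and a 5.2-fold lower number (0.72 log units; beyond the scatter) from compound 4 to compound 1, 5.0-fold (0.69 log units) apart, beyond the scatter of two such steps.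
The two changes therefore do not add up across these compounds: either one alone separates a compound from compound 1, the strongest of the set, and compound 2, which carries both, stays within the scatter of compound 4, which in turn stays within the scatter of compound 3.

Still open, going by these compounds, is whether a chloro or methoxy group in the place of the fluoro would behave as the fluoro does, and whether a longer chain carrying the amine would keep the number of compound 1, which stands at 95000 nM. The gap in this set also rests on compound 1 alone, so the compounds shown cannot tell whether other groups on the phenoxy ring or the amine nitrogen would stand with it or with the rest.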